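Topoisomerase inhibition: pyridine-linked aryl series, estimating compound 4

The compounds below may be only part of what the source reports. "The series", "measured", "known", "first", "only" and "open" are said of these compounds alone.

Measured compounds:
compound 1 `Clc1ccc(-c2cc(-c3ccsc3)nc(-c3ccccc3Cl)c2)o1` – 0%
compound 2 `Clc1ccc(-c2cc(-c3cccnc3)nc(-c3cccs3)c2)o1` – 25.8%
compound 3 `Clc1ccc(-c2cc(-c3ccoc3)cc(-c3cccs3)n2)cc1` – 0%

In an assay on isolated protein for inhibition of DNA topoisomerase 1 (Homo sapiens), tested at 100 uM (on this read-out higher numbers stand for a stronger effect at the one concentration tested and lower numbers for a weaker effect), compound 1 gives 0%, level at the digits reported with compound 3, which in this assay gives 0%; the two together stand at the bottom of the three numbers, and their gap lies within the scatter. Going by the values given here, compound 2 gives 25.8% in this assay, the only number beyond the scatter above compound 1. Among the compounds with values here, no two measured compounds differ in only one place, so no single step has been measured in this set.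

Compound 4 `Cc1ccc(-c2cc(-c3ccc(Cl)o3)cc(-c3ccsc3)n2)cc1` is not yet measured. It differs from compound 1 as follows: 4-methylphenyl in place of 2-chlorophenyl on an aromatic carbon. Nothing in the three measured compounds isolates the effect of a change at this position, so no direction can be read from them.

The expected step in this assay is a number 5 percentage points higher from compound 1 to compound 4 (within the scatter), a step estimated not to exceed the scatter, because compound 1 stands at 0% and the closest measured neighbour, compound 3, is also at the bottom. Compound 4 is therefore expected to give about 5% in this assay, with a range from 0% to 22%.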

Compound 4, a percentage reported as inhibition, at one concentration (the size of the read-out at that concentration, not a potency): 2.6%
For compound 4 the middle estimate is 2.4 percentage points above the measured one; the range from low to high includes it.
By their numbers in this assay, from the lowest: compounds 1, 3 and 4 (each within the scatter of the next); then compound 2.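

In this assay, going by these compounds alone, the exchange of 2-chlorophenyl for 4-methylphenyl on the aromatic carbon next to the ring nitrogen gives a number 2.6 percentage points higher from compound 1 to compound 4 (within the scatter) as the first single-place step. At this position, then, a phenyl ring carrying chlorine and a phenyl ring carrying methyl, alike in heavy-atom count and with no hydrogen-bond donors or acceptors, are not told apart by this read-out, although the step changes both the substituent and its place on the phenyl ring, and those two changes cannot be separated here. No measured evidence bears on why the step is this small.

Going by these compounds, whether a 4-chlorophenyl or 2-methylphenyl group would match these two, or whether an aminomethyl group or a carboxylic acid on this phenyl ring would shift the number beyond the scatter, remains open. Compound 2 differs from compound 1 in more than one place, so which of its differences goes with its higher number also stays unresolved.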